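Compound 3 against the low value of compound 2

The compounds below may be only part of what the source reports. "The series", "measured", "known", "first", "only" and "open" are said of these compounds alone.

Compound 1 `O=C(O)c1cn(C2CC2)c2c(Cl)c(N3CCCC3)c(F)cc2c1=O`: 150 ug/mL
Compound 2 `NC1CCCN(c2c(F)cc3c(=O)c(C(=O)O)cn(C4CC4)c3c2Cl)C1`: 24 ug/mL

In a functional assay on V79 cells (Cricetulus griseus) for cytotoxicity, read by colony formation (a lower number here means a stronger inhibitor, a higher number a weaker inhibitor), compound 2 holds the lower of the two numbers, at 24 ug/mL. Compound 3 `CC1CN(c2c(F)cc3c(=O)c(C(=O)O)cn(C4CC4)c3c2Cl)CCN1` carries 3-methylpiperazin-1-yl in place of 3-aminopiperidin-1-yl on an aromatic carbon. Among the measured compounds shown here, the only measured step at this place is a 6.3-fold lower number from compound 1 to compound 2 (0.80 log units; beyond the scatter), a modest one beyond the scatter. It involves a different pair of groups, so it suggests a scale but not a direction. A step of similar or smaller size is expected, more probably upward. The estimate means a 2.1-fold higher number from compound 2 to compound 3 (0.32 log units; beyond the scatter), an expected step. For compound 3 the expected value is 50 ug/mL, with an estimated range of 16 ug/mL to 150 ug/mL.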

Compound 3, half-maximal inhibitory concentration: 45 ug/mL
Compound 3: middle estimate off by 1.1-fold (0.05 log units), on the high side; low and high end bracket the measured number.
By their numbers in this assay, from the lowest: compounds 2 and 3 (each within the scatter of the next); then compound 1.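

At this aromatic carbon, 3-methylpiperazin-1-yl and 3-aminopiperidin-1-yl, which hold the same atoms joined differently, cannot be told apart in this assay, with a 1.9-fold higher number from compound 2 to compound 3 (0.27 log units; within the scatter). Among the compounds shown here, the earlier pair showed only one six-membered ring set against pyrrolidin-1-yl, and a second now also separates from it, with a 3.3-fold lower number from compound 1 to compound 3 (0.52 log units; beyond the scatter). Nothing available explains these numbers.

As far as these compounds go, it remains open whether an unsubstituted piperazin-1-yl would stay within the scatter of compound 2. An open-chain amine, such as 2-aminoethylamino, at this carbon is equally untested by the compounds shown.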